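The source may hold more compounds than are shown below. What is called first, only, known or untested is meant among the compounds shown, and "the series" means these compounds.

Working notes on the flavone ester series

Of the compounds shown here, three have been tested in an ADME assay on cells (T-cell, Mus musculus, strain BALB/c) for cytotoxicity, read by MTT assay, with a stated time of 48 h; a higher number here means that more compound is tolerated, a lower number that less compound is tolerated. Compound 1 `COC(=O)c1ccc(C)cc1OC(=O)COc1cc(O)c2c(=O)cc(-c3ccccc3)oc2c1` gives 250000 nM. Compound 2 `COC(=O)c1ccc(Cl)cc1OC(=O)COc1cc(O)c2c(=O)cc(-c3ccccc3)oc2c1` gives 265000 nM. Compound 3 `COC(=O)c1c(Br)cc(Br)cc1OC(=O)COc1cc(O)c2c(=O)cc(-c3ccccc3)oc2c1` gives 398000 nM. On these numbers compound 2 stands second highest of the three, nearest to compound 1 and furthest from compound 3, and both of those gaps are within the scatter. Among the measured compounds shown here, the one step between neighbours that differ in a single place is a 1.1-fold higher number from compound 1 to compound 2 (0.03 log units; within the scatter), a chloro in place of a methyl on an aromatic carbon, and it did not move the number beyond the scatter.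

Compound 4 `COC(=O)c1cc(C)ccc1OC(=O)COc1cc(O)c2c(=O)cc(-c3ccccc3)oc2c1` is the next member to be measured in this assay. It differs from compound 2 as follows: a group of 11 heavy atoms (9 carbon, 2 oxygen; one six-membered aromatic ring of carbon only) in place of a group of 11 heavy atoms (8 carbon, 2 oxygen, 1 chlorine; one six-membered aromatic ring of carbon only), on an oxygen next to a carbonyl group. The group that enters carries a methyl where the group that leaves carries a chlorine, so this change undoes the kind of swap seen from compound 1 to compound 2, and that swap stayed within the scatter. For the measured compounds named here, no step so far has gone beyond the scatter, so no step beyond the scatter is expected here either; the expected step is a 1.1-fold lower number from compound 2 to compound 4 (0.03 log units; within the scatter). For compound 4 the estimate in this assay is therefore 250000 nM, with a range from 150000 nM to 420000 nM.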

Compound 4, half-maximal cytotoxic concentration: 306000 nM
The estimate for compound 4 lay 1.2-fold (0.09 log units) below the measured number; the measured number falls inside the stated range.
By their numbers in this assay, from the lowest: compounds 1, 2, 4 and 3 (each within the scatter of the next).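

In this assay this position, on an oxygen next to a carbonyl group, can now be read through two changes of the aromatic group. Exchanging the 5-chloro-2-(methoxycarbonyl)phenyl group for the entering group gives a 1.2-fold higher number from compound 2 to compound 4 (0.06 log units; within the scatter) and so, like the earlier swap of chloro and methyl, stays within the scatter. The second change gives a 1.2-fold higher number from compound 1 to compound 4 (0.09 log units; within the scatter) between two groups with identical printed counts of heavy atoms, which shows that a different arrangement of those atoms on the aromatic ring also leaves the number within the scatter, though nothing available explains this closeness.

On these data alone, the three compounds linked by these steps carry only chloro or methyl alongside the methoxycarbonyl group, so it remains open whether an amine, a carboxylic acid or a longer alkyl chain on that ring would produce a step beyond the scatter. As far as these compounds go, it also remains open whether replacing the methoxycarbonyl group itself with an amide or a carboxylic acid would do so.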